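The compounds below may be only part of what the source reports. "The series", "measured", "known", "first", "only" and "open" are said of these compounds alone.

Measured compounds in a toxicity assay on the whole organism (strain Icem-CET (SPF Caw)) for cytotoxicity, with Mus musculus as the target; on this read-out lower numbers stand for an effect already at smaller amounts and higher numbers for an effect only at larger amounts of compound:
- compound 1 `C#CCNC(=O)/C(C)=C(\C)c1cc(OC)c(OC)c(OC)c1` gives 300 mg/kg
- compound 2 `C/C(C(=O)NC1CC1)=C(/C)c1ccc(Cl)cc1` gives > 800 mg/kg

Compound 2 does not have a number of its own in this assay: its result is only a limit, the value given being the edge of what the measurement could resolve (the limit of > 800 mg/kg in this assay, at which 1 of the 2 values shown sits). Within the data shown here, compound 1 is the only one of the two with a numeric result, and the two compounds differ in several places at once, so no single step between them can be read off.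

Compound 3 `C/C(C(=O)NC1CC1)=C(/C)c1ccc(C)cc1` is the compound that remains to be measured. It differs from compound 2 in one place: methyl in place of chloro on an aromatic carbon. One small uncharged group is swapped for another of the same size, with no change in rings, charge or hydrogen bonding.

With no comparable step shown among the measured compounds, the change from compound 2 to compound 3 in this assay is expected to stay within the usual scatter, in no particular direction, and the estimated step is a number no higher from compound 2 to compound 3 (the limit leaves the size open). Compound 3 is therefore expected to give about 800 mg/kg, within a range from 400 mg/kg to 1600 mg/kg, with a fair chance that the assay again reports only a limit.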

Compound 3, dose for half-maximal effect: 300 mg/kg
Compound 3: the middle estimate sits 2.7-fold (0.43 log units) above what was measured; the whole stated range lies above it.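

In this assay, swapping a single group on an aromatic carbon, para to a large group, gives an at least 2.6-fold lower number from compound 2 to compound 3 (0.42 log units; beyond the scatter), with methyl in place of chloro. The earlier compounds shown here could not show this, and it means that this position matters in the whole animal: even two groups that match in heavy-atom count, in having no ring, in hydrogen-bond donors and acceptors, and in net charge are told apart here. The result for compound 2 is a limit, so the step has a smallest size but no known full size: the limit of > 800 mg/kg in this assay, at which 1 of the 3 values shown sits.

The compounds shown leave open how other groups at this position would behave, such as fluoro, methoxy or an amine, and whether any of them would fall closer to methyl or to chloro. They also do not show why the swap shifts the read-out, or whether the same swap would have a similar effect in a compound carrying a different group on the amide nitrogen.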